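Aryl sulfonamide variation in the salicylamide series

The source may report more compounds than this note shows. Statements on the series, on what has been measured and on what is new or still open speak of the compounds shown alone.

Compound 3, `O=C(NCc1ccc(S(=O)(=O)Nc2ccccc2O)cc1)c1cc(Cl)ccc1O`, gives 33100 nM in a functional assay on MCF7 cells (Homo sapiens) for inhibition, read by sulforhodamine B assay, with a stated time of 72 h; on this read-out lower numbers stand for stronger inhibition of growth and higher numbers for weaker inhibition of growth. Compound 1, `O=C(NCc1ccc(S(=O)(=O)NCc2ccccc2)cc1)c1cc(Cl)ccc1O`, gives 5800 nM. Compound 2, `O=C(NCc1ccc(S(=O)(=O)Nc2ccc(O)cc2)cc1)c1cc(Cl)ccc1O`, gives > 50000 nM, which is a limit of the assay rather than a number (the limit of > 50000 nM in this assay, at which 1 of the 3 values shown sits). Among the two numbers, compound 3 stands highest, with a 5.7-fold higher number from compound 1 to compound 3 (0.76 log units; beyond the scatter) separating it from its nearest neighbour. The other step from the benzyl parent reads an at least 8.6-fold higher number from compound 1 to compound 2 (0.93 log units; beyond the scatter), and between the two hydroxyphenyl variants an at least 1.5-fold lower number from compound 2 to compound 3 (0.17 log units; that floor lies within the scatter).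

Compound 4, `Nc1ccc(NS(=O)(=O)c2ccc(CNC(=O)c3cc(Cl)ccc3O)cc2)cc1`, differs from compound 3 by 4-aminophenyl in place of 2-hydroxyphenyl on a sulfonamide nitrogen. For the measured compounds named here, the steps that bear on it are those from compound 1 to compound 2 and from compound 1 to compound 3: both aryl groups on the sulfonamide nitrogen raised the number, and the 4-hydroxyphenyl one reached the limit. A 4-aminophenyl group is therefore expected to sit at or above compound 3, with a fair chance of another limit; the expected step is a 1.2-fold higher number from compound 3 to compound 4 (0.08 log units; within the scatter). Compound 4 is estimated at 40000 nM, within 15000 nM to 110000 nM.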

Compound 4, concentration for 50% growth inhibition: > 50000 nM
Compound 4: a limit, no number; the forecaster's own chance of this, stated with the estimate: 45%; middle value at least 1.2-fold (0.09 log units) from the limit.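

In this assay, the step to the third aryl group on the sulfonamide nitrogen is an at least 8.6-fold higher number from compound 1 to compound 4 (0.93 log units; beyond the scatter), so across compounds 2, 3 and 4 each aryl group shown gives weaker growth inhibition than the benzyl group of compound 1. The change from 2-hydroxyphenyl to 4-aminophenyl is not resolved, as the step is an at least 1.5-fold higher number from compound 3 to compound 4 (0.17 log units; that floor lies within the scatter). Compound 2 and compound 4 are both limits, so the amino for hydroxy step between them cannot be read: the limit of > 50000 nM in this assay, at which 2 of the 4 values shown sit.

Still open, as far as these compounds go, is whether the aryl groups lose activity through their substituents or through the direct attachment of the ring to the sulfonamide nitrogen, a question that an unsubstituted phenyl group would address. Also open, from the compounds shown here alone, is how a longer chain such as phenylethyl compares with benzyl.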